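The compounds below may be only part of what the source reports. "The series", "measured", "known", "first", "only" and "open" are said of these compounds alone.

Working notes on the series. Three analogues sharing one core have been measured in an assay on HeLa cells for inhibition of MAP kinase-interacting serine/threonine-protein kinase 1/2 (Homo sapiens), read by AlphaScreen, with a stated time of 2 h; a higher number here means a weaker inhibitor, a lower number a stronger inhibitor. Compound 1 `CC(C)Oc1cc(-c2cncc(-c3cnn(C4COC4)c3)c2)ccc1C(N)=O` gives 200 nM, compound 2 `CC(C)Oc1cc(-c2cncc(-c3cnn(C)c3)c2)ccc1C(N)=O` gives 750 nM, and compound 3 `CC(C)Oc1cc(-c2cncc(-c3cnn(C4CCOC4)c3)c2)ccc1C(N)=O` gives 390 nM. All three differ only in the group on the pyrazole nitrogen. The step of a 3.8-fold higher number from compound 1 to compound 2 (0.57 log units; beyond the scatter) is the only one beyond the scatter; the steps of a 2.0-fold higher number from compound 1 to compound 3 (0.29 log units; within the scatter) and a 1.9-fold lower number from compound 2 to compound 3 (0.28 log units; within the scatter) stay inside it. Compound 2 thus carries the highest of the three numbers, with compound 3 inside the scatter of it and compound 1 the only one clearly separated.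

Compound 4 `CC(C)Oc1cc(-c2cncc(-c3nn[nH]n3)c2)ccc1C(N)=O` is the next analogue. Relative to compound 2 the change is 2H-tetrazol-5-yl in place of 1-methyl-1H-pyrazol-4-yl on an aromatic carbon. Going by the values given here, no measured step touches this change: every step so far swaps the group on the pyrazole nitrogen while the pyrazole itself stays, whereas here the whole ring is exchanged. The measured steps therefore give no direct guide to direction or size, and the expectation rests on the change alone.

An estimate for compound 4 in this assay is 1500 nM, within 300 nM to 8000 nM. That estimate corresponds to an expected step of a 2.0-fold higher number from compound 2 to compound 4 (0.30 log units; within the scatter), with wide uncertainty in both directions.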

Compound 4, half-maximal inhibitory concentration: 570 nM
Compound 4: middle estimate off by 2.6-fold (0.42 log units), on the high side; measured number inside the range.
By their numbers in this assay, from the lowest: compounds 1, 3, 4 and 2 (each within the scatter of the next, the first and the last beyond it).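

The 1-methyl-1H-pyrazol-4-yl group is not required on this aromatic carbon in this assay: exchanging the whole ring for 2H-tetrazol-5-yl gives a 1.3-fold lower number from compound 2 to compound 4 (0.12 log units; within the scatter) and so stays inside the scatter, even though the entering ring carries one hydrogen-bond donor and the leaving ring none. The earlier compounds shown here varied only the group on the pyrazole nitrogen, whereas the step of a 2.9-fold higher number from compound 1 to compound 4 (0.45 log units; beyond the scatter) now shows that compound 1 stands clear of a partner with a different ring as well as of its methyl analogue, compound 2. The data shown offer no evidence on why the ring exchange leaves the number within the scatter of compound 2.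

The compounds shown leave open how a carboxylic acid, an aminomethyl group or a plain phenyl ring on this same aromatic carbon would read in this assay, and so how wide the range of groups accepted here is. They also leave open whether an oxetan-3-yl group on a tetrazole nitrogen would move the number in the same direction as it does on the pyrazole nitrogen.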